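Hydroxy added to the side chain of compound 2

The compounds below may be only part of what the source reports. "The series", "measured", "known", "first", "only" and "open" are said of these compounds alone.

Compound 2 `COC(=O)[C@@H](C)NC(=O)Cn1cc(C2=C(c3c[nH]c4ccccc34)C(=O)N(C)C2=O)c2ccccc21` gives the lowest of the three numbers recorded in a functional assay on HCT-8 cells (Homo sapiens) for cytotoxicity, read by MTT assay, with a stated time of 24 h; on this read-out lower numbers stand for stronger inhibition and higher numbers for weaker inhibition: compound 2 gives 21400 nM. Compound 1 `COC(=O)[C@H](NC(=O)Cn1cc(C2=C(c3c[nH]c4ccccc34)C(=O)N(C)C2=O)c2ccccc21)[C@@H](C)O` gives 23400 nM in this assay, and the step of a 1.1-fold lower number from compound 1 to compound 2 (0.04 log units; within the scatter) is within the scatter, so these two compounds are not told apart. Compound 3 `COC(=O)CCNC(=O)Cn1cc(C2=C(c3c[nH]c4ccccc34)C(=O)N(C)C2=O)c2ccccc21` gives 50900 nM; the steps of a 2.4-fold higher number from compound 2 to compound 3 (0.38 log units; beyond the scatter) and a 2.2-fold higher number from compound 1 to compound 3 (0.34 log units; beyond the scatter) are modest.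

Compound 4 `COC(=O)[C@@H](CO)NC(=O)Cn1cc(C2=C(c3c[nH]c4ccccc34)C(=O)N(C)C2=O)c2ccccc21` has not yet been measured in this assay. It differs from compound 2 by hydroxy in place of hydrogen on a saturated chain carbon, two bonds along the chain from an amide-type nitrogen and a carbonyl carbon. Within the data shown here, the step that bears on this change is the one from compound 1 to compound 2, where methyl replaced 1-hydroxyethyl at a comparable position and the step of a 1.1-fold lower number from compound 1 to compound 2 (0.04 log units; within the scatter) stayed within the scatter; a hydroxy at this part of the chain thus made no detectable difference there. Among the measured compounds shown here, in compound 4 the hydroxy enters as hydroxymethyl rather than 1-hydroxyethyl, and no measured compound shows whether that matters. Compound 4 is therefore expected to give a number close to that of compound 2, and the expected step of a 1.0-fold higher number from compound 2 to compound 4 (0.01 log units; within the scatter) lies within the scatter. The estimate for compound 4 in this assay is 22000 nM, with a range from 11000 nM to 45000 nM.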

Compound 4, half-maximal inhibitory concentration: 22900 nM
Beside the measured number, compound 4's estimate is 1.0-fold (0.02 log units) below it, and the stated range covers the measured number.
By their numbers in this assay, from the lowest: compounds 2, 4 and 1 (each within the scatter of the next); then compound 3.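

Among these compounds, compound 4 gives the first direct reading of the hydroxy alone: in this assay, placing it on the saturated chain carbon, two bonds along the chain from an amide-type nitrogen and a carbonyl carbon, turns methyl into hydroxymethyl and gives a 1.1-fold higher number from compound 2 to compound 4 (0.03 log units; within the scatter), so the change leaves compound 2 and compound 4 not told apart. Among the compounds shown here, the hydroxymethyl and 1-hydroxyethyl forms of this side chain are also not told apart, with hydrogen in place of methyl on the carbon carrying the hydroxy giving a 1.0-fold lower number from compound 1 to compound 4 (0.01 log units; within the scatter), which answers the question left open by the earlier compounds. The 2-hydroxy-1-(methoxycarbonyl)ethyl group in place of 2-(methoxycarbonyl)ethyl on the amide-type nitrogen gives a 2.2-fold lower number from compound 3 to compound 4 (0.35 log units; beyond the scatter), a modest step that places compound 4 with compound 1 and compound 2 and apart from compound 3.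

Nothing available here explains why the hydroxy leaves the number within the scatter. The compounds shown leave open whether an amine or a carboxylic acid at this position, or a longer chain carrying the hydroxy, would separate from compound 2 in this assay.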